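Compound 2 to compound 4: losing the dimethylamino group

The source may hold more compounds than are shown below. What is called first, only, known or untested is meant among the compounds shown, and "the series" means these compounds.

Values in a functional assay on Caco-2 cells (Homo sapiens), read by MTT assay, with a stated time of 48 h; a lower number here means a stronger inhibitor, a higher number a weaker inhibitor:
- compound 1 `CCN(CC)CCNC(=O)c1ccc(C(CC)(CC)c2ccc(OCC(=O)C(C)(C)C)c(C)c2)n1CC`: 1600 nM
- compound 2 `CCn1c(C(=O)NCCN(C)C)ccc1C(CC)(CC)c1ccc(OCC(O)C(C)(C)C)c(C)c1`: 1300 nM
- compound 3 `CCn1c(C(=O)NCC(OC)OC)ccc1C(CC)(CC)c1ccc(OCC(O)C(C)(C)C)c(C)c1`: > 50000 nM (a limit of the assay)

Only two of the three results are numbers. Compound 2 at 1300 nM and compound 1 at 1600 nM lie within the scatter of each other.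

Compound 4 `CCn1c(C(=O)N(C)CCC#N)ccc1C(CC)(CC)c1ccc(OCC(O)C(C)(C)C)c(C)c1` carries (2-cyanoethyl)(methyl)amino in place of the (2-(dimethylamino)ethyl)amino of compound 2, on a carbonyl carbon ((2-cyanoethyl)(methyl)amino in place of (2-(dimethylamino)ethyl)amino on a carbonyl carbon). The amide hydrogen is gone, and a nitrile enters.

For the measured compounds named here, one measured step bears on this change: an at least 38-fold higher number from compound 2 to compound 3 (1.58 log units; beyond the scatter). It is large, and the dimethylamino group leaves there too. Compound 3 gives > 50000 nM, which is a limit of the assay and not a number.

Going by the values given here, the new group in compound 4 differs from the one in compound 3, and a single step is thin support. Even so, a large move to a higher number is expected in this assay, on the strength of an at least 38-fold higher number from compound 2 to compound 3 (1.58 log units; beyond the scatter). The estimated step is a 19-fold higher number from compound 2 to compound 4 (1.28 log units; beyond the scatter). For compound 4 the expected value is 25000 nM, with an estimated range of 6000 nM to 50000 nM.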

Compound 4, half-maximal inhibitory concentration: > 50000 nM
Compound 4 gave a limit, no number (the forecaster's own chance of this, stated with the estimate: 40%); middle value at least 2.0-fold (0.30 log units) away from the limit.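

In this assay compound 4 gives > 50000 nM, a limit of the assay and not a number. Replacing (2-(dimethylamino)ethyl)amino with (2-cyanoethyl)(methyl)amino on a carbonyl carbon gives an at least 38-fold higher number from compound 2 to compound 4 (1.58 log units; beyond the scatter), so a large move now appears with a second entering group, one that shares no atoms of the dimethoxymethyl end of the earlier step and has the same count of heavy atoms as the group it replaces. Compound 3 and compound 4 therefore end alike in this assay, and the step between them cannot be read, so no order between the two entering groups can be given: the limit of > 50000 nM in this assay, at which 2 of the 4 values shown sit.

Compound 4 loses the dimethylamino group and the amide hydrogen in one change, and the compounds shown do not separate these two losses from each other or from the entry of the nitrile. Also open, as far as these compounds go, is whether a different amine at this carbonyl carbon, such as a piperidine or a morpholine, or a longer chain ending in dimethylamino, would stay close to compound 2 at 1300 nM.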